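A few compounds are considered here, and "the series" means these few. Any claim that something is new, unique, unknown or untested is made for them only; others in the source may bear on it.

Among the compounds with values here, compound 3, `COC(=O)[C@H](C)Nc1cc(CS(=O)(=O)/C=C/c2c(OC)cc(OC)cc2OC)ccc1OC`, is one of three compounds measured in a functional assay on DU-145 cells (Homo sapiens) for cytotoxicity, read by trypan blue exclusion, with a stated time of 96 h; on this read-out higher numbers stand for weaker inhibition and lower numbers for stronger inhibition. Compound 1, `COc1ccc(CS(=O)(=O)/C=C/c2c(OC)cc(OC)cc2OC)c(N)c1`, gives 25 nM in this assay, and compound 2, `COc1ccc(CS(=O)(=O)/C=C/c2cc(OC)c(OC)c(OC)c2)cc1N`, gives 3000 nM. Compound 3 itself gives 750 nM, which places it second highest of the three numbers: its gap to compound 2 is beyond the scatter, and so is its much larger gap to compound 1. Compound 4, `COc1cc(OC)c(/C=C/S(=O)(=O)Cc2ccc(OC)c(NC(C(=O)O)c3ccccc3)c2)c(OC)c1`, has not yet been measured in this assay. It differs from compound 3 in one place: carboxy(phenyl)methyl in place of 1-(methoxycarbonyl)ethyl on a nitrogen on an aromatic ring. Within the data shown here, no measured pair shows what such a change does to this assay, so the expectation for compound 4 rests only on the value of compound 3 and the weak anchor that changes at this nitrogen gave between compound 1 and compound 3. The step is expected to be a 2.0-fold higher number from compound 3 to compound 4 (0.30 log units; within the scatter), towards a somewhat higher number, though it could fall within the scatter. Compound 4 is therefore expected to give about 1500 nM, with a range from 300 nM to 8000 nM.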

Compound 4, half-maximal inhibitory concentration: 20 nM
Estimate against measurement, compound 4: 75-fold (1.88 log units) above; the measured number lies below the stated range.
By their numbers in this assay, from the lowest: compounds 4 and 1 (each within the scatter of the next); then compound 3; then compound 2.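

In this assay, carboxy(phenyl)methyl in place of 1-(methoxycarbonyl)ethyl on a nitrogen on an aromatic ring gives a 38-fold lower number from compound 3 to compound 4 (1.57 log units; beyond the scatter), a large step. Compound 3 alone had shown a substituent on this nitrogen, and this pair now shows that the group carried there can move the number strongly, and that a larger group with a six-membered aromatic ring need not raise it. Nothing measured here explains why this change has so large an effect.

The change alters several features at once, so the compounds shown do not separate the part played by the phenyl ring from that of the free carboxylic acid, or the part of the defined stereocentre that leaves with compound 3. A 1-carboxyethyl group or a methyl ester of the carboxy(phenyl)methyl group on this nitrogen would tell these parts apart.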